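The source may hold more compounds than are shown below. What is called first, only, known or untested is meant among the compounds shown, and "the series" means these compounds.

Measured compounds:
compound 1, `CCc1cccc(C[C@H](O)/C=C/[C@H]2COC(=O)N2CCSCCCC(=O)O)c1`: 18 nM
compound 2, `COCc1cccc(C[C@H](O)/C=C/[C@H]2CSC(=O)N2CCSCCCC(=O)O)c1`: 2.4 nM

In a functional assay on CHO cells for agonist activity at prostaglandin E2 receptor EP4 subtype (Rattus norvegicus), read by cAMP accumulation and immunoassay, with a stated time of 10 min (on this read-out lower numbers stand for an effect already at smaller amounts and higher numbers for an effect only at larger amounts of compound), compound 1 gives 18 nM, the higher of the two numbers, while compound 2 gives 2.4 nM, a gap beyond the scatter. These two differ in more than one place, so nothing is drawn from their gap. Compound 3, `O=C(O)CCCSCCN1C(=O)OC[C@@H]1/C=C/[C@@H](O)Cc1cccc(C(F)(F)F)c1`, is not yet measured. It arises from compound 1 by one change: trifluoromethyl in place of ethyl on an aromatic carbon. Among the compounds with values here, no measured pair shows this change, so the numbers point in no direction. The expected step is a 1.2-fold lower number from compound 1 to compound 3 (0.08 log units; within the scatter), within or close to the scatter. Compound 3 is expected to give about 15 nM, in the range 5 nM to 50 nM.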

Compound 3, half-maximal effective concentration: 12 nM
Compound 3: middle estimate off by 1.3-fold (0.10 log units), on the high side, and the stated range covers the measured number.
By their numbers in this assay, from the lowest: compound 2; then compounds 3 and 1 (each within the scatter of the next).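

Putting trifluoromethyl in place of ethyl on an aromatic carbon gives a 1.5-fold lower number from compound 1 to compound 3 (0.18 log units; within the scatter) in this assay. This is the only comparison shown that changes this position alone, and it cannot tell the two groups apart, so the larger trifluoromethyl group is accepted here without a change beyond the scatter. Nothing measured here bears on why the two groups read alike. Still open, as far as these compounds go, is how a hydroxyl, an amine or a nitrile on this carbon would read, and whether the same swap would give a similar step on the core of compound 2.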